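One Methoxy Fewer: An Expectation for Compound 4

The compounds below may be only part of what the source reports. "The series", "measured", "known", "first", "only" and "open" are said of these compounds alone.

Of the compounds shown here, three have been measured in a functional assay on SNB-19 cells (Homo sapiens) for cytotoxicity, read by sulforhodamine B assay, with a stated time of 48 h, tested at 1 uM; on this read-out higher numbers stand for a weaker effect at the one concentration tested and lower numbers for a stronger effect. In this assay compound 1 `COc1ccc(-c2cc(/C=C/C(=O)c3ccc(N)cc3)[nH]n2)cc1` gives 75%, compound 2 `COc1ccc(-c2cc(/C=C/C(=O)c3ccc(N)cc3)[nH]n2)cc1OC` gives 84%, and compound 3 `COc1cc(C(=O)/C=C/c2cc(-c3cc(OC)c(OC)c(OC)c3)n[nH]2)cc(OC)c1OC` gives 82%. The change from compound 2 to compound 1 is hydrogen in place of methoxy on an aromatic carbon, and it produced a number 9 percentage points lower from compound 2 to compound 1 (within the scatter). Compound 4 `COc1ccc(-c2cc(/C=C/C(=O)c3cc(OC)c(OC)c(OC)c3)[nH]n2)cc1OC` has not yet been measured; it differs from compound 3 by hydrogen in place of methoxy on an aromatic carbon, the same kind of change, although here the place is also meta to a methoxy group. The difference between the cores of compound 2 and compound 3 is not broken down here. Because the earlier step of a number 9 percentage points lower from compound 2 to compound 1 (within the scatter) stayed within the scatter, compound 4 is expected to show a step of a number 6 percentage points lower from compound 3 to compound 4 (within the scatter) in this assay. Compound 4 is therefore estimated at 76%, lying between 62% and 90%.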

Compound 4, a percentage reported as activity, at one concentration (the size of the read-out at that concentration, not a potency): 77%
Compound 4: middle estimate off by 1 percentage points, on the low side, within the range that was stated.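

In this assay, hydrogen in place of methoxy on an aromatic carbon gives a number 5 percentage points lower from compound 3 to compound 4 (within the scatter), and this step can be set beside the one seen on the other core: the same change on two cores in this assay, a number 9 percentage points lower (within the scatter) from compound 2 to compound 1 and a number 5 percentage points lower (within the scatter) from compound 3 to compound 4, 4 percentage points apart, within the scatter of two such steps The change therefore reads alike on these two cores, with no difference between them that the assay can resolve. Each step also lies within the scatter on its own; the pair does not show that the change has a real effect on either core, and two cores set no rule for the wider series.

The compounds shown leave open what a hydroxy group, a chlorine atom or a longer chain such as ethoxy would give in place of the methoxy on either core. They also leave open how the same change would read at any other concentration.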